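The compounds below may be only part of what the source reports. "The series", "measured", "known", "first", "only" and "open" are said of these compounds alone.

Measured in a functional assay on Huh-7 cells (Homo sapiens) for inhibition, read by sulforhodamine B assay, with a stated time of 72 h; a lower number here means a stronger inhibitor, a higher number a weaker inhibitor:

compound 1 `CC(c1ccc(-c2ccccc2)c(F)c1)c1nnc2n1N=C(c1ccc(OC(F)(F)F)cc1)CS2`: 8400 nM
compound 2 `COc1ccc2cc(C(C)c3nnc4n3N=C(c3ccc(Br)cc3)CS4)ccc2c1`: 9300 nM
compound 3 `CC(C)Cc1ccc(C(C)c2nnc3n2N=C(c2ccc(Cl)cc2)CS3)cc1`: 5700 nM

All three compounds share the same core and differ at the two aryl groups attached to it. Compound 1 gives a number that neither compound 2 nor compound 3 separates from beyond the usual scatter of this assay: the three values lie close together, and no ordering among them can be read from these figures.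

The unmeasured compound 4 `CC(c1ccc(-c2ccccc2)c(F)c1)c1nnc2n1N=C(c1ccc(Cl)cc1)CS2` keeps the biphenyl side of compound 1 unchanged and alters only the other aryl group: chloro in place of trifluoromethoxy on an aromatic carbon. Among the compounds with values here, the same 4-chlorophenyl group appears in compound 3, which carries a different substituent on its other aromatic ring, so no single-change step to a measured compound exists for this replacement. Compound 3, with its 4-chlorophenyl group, gives 5700 nM, and compound 2, with a 4-bromophenyl group, gives 9300 nM, both within the scatter of compound 1. On this basis the step in this assay is expected to be small, with no direction beyond the scatter. Compound 4 is therefore estimated at 7000 nM, within a range of 3000 nM to 16000 nM, which is a step of a 1.2-fold lower number from compound 1 to compound 4 (0.08 log units; within the scatter).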

Compound 4, half-maximal inhibitory concentration: 3900 nM
Compound 4: the middle estimate sits 1.8-fold (0.25 log units) above what was measured; low and high end bracket the measured number.
By their numbers in this assay, from the lowest: compounds 4, 3, 1 and 2 (each within the scatter of the next, the first and the last beyond it).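

In this assay, with the biphenyl side held fixed, chloro in place of trifluoromethoxy gives a 2.2-fold lower number from compound 1 to compound 4 (0.33 log units; beyond the scatter), a modest step. Within the data shown here, this is the only comparison here in which compounds differ in one place, and it shows that the group on this aromatic carbon, para to a large group, can move the number on its own; the earlier compounds differed at both aryl groups, so their values could not separate this position from the other side of the molecule. The compounds shown include no measurement that could explain the step.

Among these compounds, this single pair cannot tell whether the same replacement would give a similar step with a different group on the other aromatic ring, such as the one carried by compound 3. It also leaves open how the biphenyl series would respond to bromo, the group found at this place in compound 2, or to a nitrile, a methoxy group or an amine on this aromatic carbon.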